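A Fluorobenzyl Swap on a Compound at the Limit

The compounds below may be only part of what the source reports. "The series", "measured", "known", "first", "only" and "open" are said of these compounds alone.

In a functional assay on SK-MEL-28 cells (Homo sapiens) for inhibition, read by MTT assay, with a stated time of 48 h (a lower number here means a stronger inhibitor, a higher number a weaker inhibitor), the measured compounds read as follows
- Compound 1 `O=C1N/C(=N\Cc2ccccc2)S/C1=C1/CCNC(=O)c2[nH]ccc21` gives 38400 nM
- Compound 2 `O=C1N/C(=N\Cc2ccc(C(F)(F)F)cc2)S/C1=C1/CCNC(=O)c2[nH]ccc21` gives > 100000 nM (a limit)
- Compound 3 `O=C1N/C(=N\Cc2ccccc2Cl)S/C1=C1/CCNC(=O)c2[nH]ccc21` gives > 100000 nM (a limit)

Compound 3 stands at the limit of > 100000 nM in this assay, at which 2 of the 3 values shown sit, and so has a limit rather than a number. The step to compound 4 `O=C1N/C(=N\Cc2ccc(F)cc2)S/C1=C1/CCNC(=O)c2[nH]ccc21` changes one group: 4-fluorophenyl in place of 2-chlorophenyl on a saturated chain carbon bound to a double-bonded nitrogen which reads in words as 4-fluorophenyl in place of 2-chlorophenyl on a saturated chain carbon bound to a double-bonded nitrogen.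

Within the data shown here, two measured steps bear on this change, and both start from compound 1. One is an at least 2.6-fold higher number from compound 1 to compound 2 (0.41 log units; beyond the scatter) and the other is an at least 2.6-fold higher number from compound 1 to compound 3 (0.41 log units; beyond the scatter) and both lie beyond the scatter. Neither involves fluoro, so they guide the estimate only loosely. Compound 4 also carries a substituent on the aromatic ring, so a number higher than that of compound 1 is expected, on the evidence of an at least 2.6-fold higher number from compound 1 to compound 3 (0.41 log units; beyond the scatter) and its companion step. A reading modestly under the limit is the expectation, though a further limit would be no surprise. This expected step an at least 1.5-fold lower number from compound 3 to compound 4 (0.18 log units; that floor lies within the scatter) has a loose size and one of its ends is a limit. For compound 4 the estimated value is 65000 nM with an expected range of 25000 nM to 100000 nM in this assay for now.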

Compound 4, half-maximal inhibitory concentration: 11200 nM
For compound 4 the middle estimate is 5.8-fold (0.76 log units) above the measured one; the whole stated range lies above it.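

In this assay, compound 4 is the first compound shown in which a substituent on the benzyl ring lowers the number rather than raising it, with fluoro in place of hydrogen giving a 3.4-fold lower number from compound 1 to compound 4 (0.54 log units; beyond the scatter). A substituent on this ring therefore does not in itself cost activity, and the outcome depends on which group is present: the change from 2-chlorobenzyl to 4-fluorobenzyl gives an at least 8.9-fold lower number from compound 3 to compound 4 (0.95 log units; beyond the scatter), and fluoro in place of trifluoromethyl gives an at least 8.9-fold lower number from compound 2 to compound 4 (0.95 log units; beyond the scatter). These last two steps are floors and not exact sizes, because compound 2 and compound 3 each have a limit rather than a number: the limit of > 100000 nM in this assay, at which 2 of the 4 values shown sit.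

The compounds shown do not settle whether the gain of compound 4 over compound 3 comes from the change of halogen or from the change of its place on the ring, as 2-chlorophenyl and 4-fluorophenyl differ in both. From the compounds shown here alone, it also remains open how this position would respond to a methoxy group, an amine or a carboxylic acid on the ring, and whether any such group would go beyond fluoro.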